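The source may report more compounds than this note shows. Statements on the series, on what has been measured and on what is new or still open speak of the compounds shown alone.

Compound 1 `CC(C)(C)OC(=O)N1CCC(Oc2cccc3c2ccn3-c2ccc(S(C)(=O)=O)cc2)CC1` gives, in a functional assay on CHO-K1 cells with Glucose-dependent insulinotropic receptor (Homo sapiens) as the target, read by a luciferase reporter, with a stated time of 5 h (on this read-out lower numbers stand for smaller maximal responses and higher numbers for larger maximal responses), a reading of 28%. Compound 2 `CC(C)OC(=O)N1CCC(Oc2ncnc3c2CCN3c2ccc(C#N)cc2F)CC1` gives 134% in this assay. Compound 3 `CCOC(=O)N1CCC(Oc2ncnc3c2CCN3c2ccc(S(C)(=O)=O)cc2F)CC1` gives 135% in this assay, the highest of the three numbers seen; its nearest neighbour is compound 2, whose number is lower by a margin that stays within the scatter, while its furthest is compound 1, whose number lies far lower, well beyond the scatter. Compound 4 `CC(C)c1noc(N2CCC(Oc3ncnc4c3CCN4c3ccc(S(C)(=O)=O)cc3F)CC2)n1` has not yet been measured. It differs from compound 3 in one place: 3-isopropyl-1,2,4-oxadiazol-5-yl in place of ethoxycarbonyl on an amine nitrogen in a ring. Within the data shown here, no two measured compounds differ from each other in a single place, so no step of this kind has been observed, and the expectation for compound 4 rests on the high readings of compound 2 and compound 3, which share the rest of the structure with compound 4. The step of a number 10 percentage points lower from compound 3 to compound 4 (within the scatter) is expected to be small, with no change beyond the scatter. Compound 4 is expected to give about 125% in this assay, within a range from 90% to 150%.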

Compound 4, largest response reached (reported as percent of maximum), in percent of the reference or control that the assay uses: 124%
The estimate for compound 4 lay 1 percentage points above the measured number; low and high end bracket the measured number.
By their numbers in this assay, from the lowest: compound 1; then compounds 4, 2 and 3 (each within the scatter of the next, the first and the last beyond it).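

In this assay, the change to 3-isopropyl-1,2,4-oxadiazol-5-yl in place of ethoxycarbonyl on an amine nitrogen in a ring gives the first single-place step seen here, a number 11 percentage points lower from compound 3 to compound 4 (beyond the scatter) and modest in size. With compound 4 still at 124%, the ethoxycarbonyl group is not required on this nitrogen for a high maximal response, even though the entering group is a five-membered aromatic ring and is larger by heavy-atom count. Nothing shown accounts for the size of this step.

As far as these compounds go, whether a methyl group in place of the isopropyl on the oxadiazole, or a simple acetyl group on the same nitrogen, would keep the response this high remains open. Also open, from the compounds shown here alone, is whether the same exchange would give a step of similar size in the nitrile-bearing compound 2.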